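Permeability notes on the aryloxy-benzimidazole acid series

The compounds below may be only part of what the source reports. "The series", "measured", "known", "first", "only" and "open" are said of these compounds alone.

Two members of the series have numbers in an ADME assay for permeability, using PAMPA, with a stated time of 4 h; a lower number here means that the compound crosses the layer more slowly, a higher number that the compound crosses the layer faster. Compound 1 `Cn1c(COc2cccc(C(=O)O)c2)nc2ccc(Oc3ccc4c(c3)OCC4)nc21` gives 9.1 10^-6 cm/s in this assay. Compound 2 `Cn1c(COc2cccc(C(=O)O)c2)nc2ccc(Oc3cccc(Cl)n3)cc21` gives 7.6 10^-6 cm/s in this assay, which is the lowest of the two numbers shown, with compound 1 nearest to it at a difference that lies within the scatter; the two values therefore show no real separation.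

Compound 3 `Cn1c(COc2cccc(C(=O)O)c2)nc2ccc(Oc3ncccc3F)cc21` is not yet measured in this assay. It differs from compound 2 in one place: 3-fluoropyridin-2-yl in place of 6-chloropyridin-2-yl on an oxygen on an aromatic ring. Going by the values given here, no measured pair tracks this kind of change, so nothing here shows its effect on this assay. Among the compounds with values here, both members measured so far sit close together, and the change keeps the ring count, heavy-atom count and acceptor count the same. The step from compound 2 to compound 3 is expected to be small, a 1.1-fold lower number from compound 2 to compound 3 (0.04 log units; within the scatter), and not beyond the scatter in either direction. Compound 3 is therefore estimated at 7 10^-6 cm/s in this assay, with a range from 3.5 10^-6 cm/s to 14 10^-6 cm/s.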

Compound 3, apparent permeability: 3.9 10^-6 cm/s
Compound 3: middle estimate off by 1.8-fold (0.25 log units), on the high side; the range from low to high includes it.
By their numbers in this assay, from the lowest: compounds 3, 2 and 1 (each within the scatter of the next, the first and the last beyond it).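

Going by these compounds alone, this is the first pair that tracks a change at this position: 3-fluoropyridin-2-yl in place of 6-chloropyridin-2-yl on an oxygen on an aromatic ring gives a 1.9-fold lower number from compound 2 to compound 3 (0.29 log units; within the scatter) in this assay and so does not leave the scatter. The two groups have the same heavy-atom count, ring and acceptor count, and this pair shows no real separation at this position. Nothing measured here bears on why the step has this size.

The pair changes both the halogen and its place on the pyridin-2-yl group, so the two changes cannot be told apart. Also open, as far as these compounds go, is what an unsubstituted pyridin-2-yl group, or an amine or methoxy group on that ring, would give in this assay at this oxygen.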